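Removing the carboxy group from compound 2

The compounds below may be only part of what the source reports. "The series", "measured", "known", "first", "only" and "open" are said of these compounds alone.

Compound 1, `COc1ccc2c(c1)OC(c1cc(OC)c(OC)c(OC)c1)C(C(=O)NC(C)(C)C)=C2`, in a functional assay for inhibition of nuclear factor NF-kappa-B complex (Homo sapiens); a higher number here means a weaker inhibitor, a lower number a stronger inhibitor: 28400 nM.
Compound 2, `COc1ccc2c(c1)OC(c1cc(OC)c(OC)c(OC)c1)C(C(=O)O)=C2`, in this assay: > 50000 nM, which is a limit of the assay and not a number.

Compound 2 thus stands at the weak end of what has been measured so far, at the limit of > 50000 nM in this assay, at which 1 of the 2 values shown sits, so its true value is known only as a limit. Among the compounds with values here, the only measured step, an at least 1.7-fold higher number from compound 1 to compound 2 (0.24 log units; that floor lies within the scatter), concerns the carbonyl group and its floor lies within the scatter, so it gives little guidance on the size of further changes.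

The next step removes that group altogether: hydrogen in place of carboxy on a double-bonded ring carbon, giving compound 3, `COc1ccc2c(c1)OC(c1cc(OC)c(OC)c(OC)c1)C=C2`. Within the data shown here, no measured step covers the loss of the carbonyl-bearing substituent itself, so the size and direction of the change in this assay cannot be read off the data; with compound 2 known only as a limit, a step in either direction cannot be excluded, nor a result that is again only a limit.

Compound 3 is therefore estimated at 50000 nM, with a range from 12000 nM to 200000 nM. The step this estimate implies is a number no higher from compound 2 to compound 3 (the limit leaves the size open), which is expected to be no more than the scatter.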

Compound 3, half-maximal inhibitory concentration: 17700 nM
Compound 3: middle estimate off by 2.8-fold (0.45 log units), on the high side; measured number inside the range.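

In this assay, within the data shown here, this double-bonded ring carbon needs no carbonyl-bearing substituent to give the activity seen so far: hydrogen in place of carboxy gives an at least 2.8-fold lower number from compound 2 to compound 3 (0.45 log units; beyond the scatter), the first step beyond the scatter. Hydrogen in place of (tert-butyl)carbamoyl gives a 1.6-fold lower number from compound 1 to compound 3 (0.21 log units; within the scatter), so at this position the two substituents cannot be told apart in this assay, and the bulky amide shows no measurable gain over hydrogen. Of the three substituents, carboxy alone stands apart, but the size of that gap stays unknown, as compound 2 carries only a limit of the assay: the limit of > 50000 nM in this assay, at which 1 of the 3 values shown sits.

From the compounds shown here alone, whether any substituent on this carbon can move the number beyond the scatter from that of compound 3, in the stronger direction, stays open: a methyl, a nitrile, a hydroxymethyl or an aminomethyl group would each test this. The compounds shown also leave open how much the shared core and its large group contribute, for example with hydroxy in place of one of the methoxy groups.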